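A Second Methyl on the 4-Methylpiperidin-1-yl Ring

The source may report more compounds than this note shows. Statements on the series, on what has been measured and on what is new or still open speak of the compounds shown alone.

In a functional assay on MEF cells (Mus musculus) for antiproliferative activity, read by luminescence, with a stated time of 16 h (a higher number here means that more compound is needed for the effect, a lower number that less compound is needed), compound 1 `O=C(Nc1ccc(S(=O)(=O)N2CCC(F)CC2)cc1)c1ccc([N+](=O)[O-])o1` gives > 20000 nM, which is a limit and not a number. Compound 2 `O=C(Nc1ccc(S(=O)(=O)N2CCC(Cl)CC2)cc1)c1ccc([N+](=O)[O-])o1` gives > 20000 nM, again a limit. Going by the values given here, compound 3 `CC1CCN(S(=O)(=O)c2ccc(NC(=O)c3ccc([N+](=O)[O-])o3)cc2)CC1` gives 16300 nM, the only true number in the set, and the limit of > 20000 nM in this assay, at which 2 of the 3 values shown sit, describes the other two. Compound 4 `CC1(C)CCN(S(=O)(=O)c2ccc(NC(=O)c3ccc([N+](=O)[O-])o3)cc2)CC1` differs from compound 3 by methyl in place of hydrogen on a saturated ring carbon. Among the compounds with values here, two measured steps bear on this change, since both bring in methyl on that carbon: an at least 1.2-fold lower number from compound 1 to compound 3 (0.08 log units; that floor lies within the scatter) and an at least 1.2-fold lower number from compound 2 to compound 3 (0.08 log units; that floor lies within the scatter). Both floors lie within the scatter, so no clear change is expected in this assay. The expected step is a 1.2-fold lower number from compound 3 to compound 4 (0.07 log units; within the scatter). Compound 4 is estimated at 14000 nM, with an expected range of 5000 nM to 30000 nM.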

Compound 4, half-maximal effective concentration: 9200 nM
Compound 4: middle estimate off by 1.5-fold (0.18 log units), on the high side; the range from low to high includes it.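

In this assay the second methyl on the 4-methylpiperidin-1-yl ring gives a 1.8-fold lower number from compound 3 to compound 4 (0.25 log units; within the scatter) and so does not clearly separate the two compounds. The 4,4-dimethylpiperidin-1-yl group does clear the scatter against the halogen-bearing rings, with an at least 2.1-fold lower number from compound 2 to compound 4 (0.33 log units; beyond the scatter) and an at least 2.1-fold lower number from compound 1 to compound 4 (0.33 log units; beyond the scatter) as the two readable comparisons. Both are floors and not full sizes, and they rest on a limit: the limit of > 20000 nM in this assay, at which 2 of the 4 values shown sit.

On these data alone, whether an ethyl, a hydroxyl or an amine on this ring carbon would lower the number further stays open. So does what a piperidine ring carrying only hydrogen there would give.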